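Swapping a halogenated ring for a hydroxy-methoxy ring

The source may report more compounds than this note shows. Statements on the series, on what has been measured and on what is new or still open speak of the compounds shown alone.

Compound 1 `CN(C)CCn1cnnc1-c1cc(Oc2ccc(NC(=O)N/N=C/c3ccc(Cl)cc3)cc2F)ccn1` gives 1870 nM in an ADME assay on WI-38 cells (Homo sapiens) for cytotoxicity, read by MTT assay, with a stated time of 72 h; a higher number here means a weaker inhibitor, a lower number a stronger inhibitor. Compound 2 `CN(C)CCn1cnnc1-c1cc(Oc2ccc(NC(=O)N/N=C/c3ccc(F)cc3Cl)cc2F)ccn1` gives 2090 nM in this assay, and the step of a 1.1-fold higher number from compound 1 to compound 2 (0.05 log units; within the scatter) lies within the scatter, so compound 2 and compound 1 cannot be told apart on these numbers. Compound 3 `COc1cc(/C=N/NC(=O)Nc2ccc(Oc3ccnc(-c4nncn4CCN(C)C)c3)c(F)c2)ccc1O` differs from compound 2 by 4-hydroxy-3-methoxyphenyl in place of 2-chloro-4-fluorophenyl on a carbon with a double bond to nitrogen. Among the measured compounds shown here, the only measured step, from compound 1 to compound 2, also reworked that ring and stayed within the scatter, so for compound 3 a step of about a 1.2-fold higher number from compound 2 to compound 3 (0.08 log units; within the scatter) is expected, not beyond the scatter. Compound 3 is thus estimated at 2500 nM, with a range from 1000 nM to 7000 nM.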

Compound 3, half-maximal inhibitory concentration: 5320 nM
The estimate for compound 3 lay 2.1-fold (0.33 log units) below the measured number; low and high end bracket the measured number.
By their numbers in this assay, from the lowest: compounds 1 and 2 (each within the scatter of the next); then compound 3.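

At this position, on a carbon with a double bond to nitrogen, changing the ring can move the number in this assay: 4-hydroxy-3-methoxyphenyl gives a 2.5-fold higher number from compound 2 to compound 3 (0.41 log units; beyond the scatter) and also a 2.8-fold higher number from compound 1 to compound 3 (0.45 log units; beyond the scatter) while the earlier swap between the two halogenated rings stayed within the scatter. Among these three compounds, only the ring carrying hydroxy and methoxy stands apart, as the weaker inhibitor. Nothing available explains this shift. Hydroxy and methoxy enter together, so their separate contributions remain open, as does the effect of an amine or a carboxylic acid on this ring.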